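This account rests on a few compounds, and the source may have more. Where it says the series, first, only, none or still open, it means among the compounds named here.

Working notes on the series. In a physicochemical assay for solubility (on this read-out lower numbers stand for lower solubility and higher numbers for higher solubility), compound 2 `CS(=O)(=O)c1ccc(-n2nc(C(F)F)c(C#N)c2-c2ccccc2)cc1` gives "not determined" (no result reported) as its result, so there is no number of its own to start from. Compound 1 `CS(=O)(=O)c1ccc(-n2nc(C(F)F)c(C#N)c2-c2ccccc2)nc1` likewise gives "not determined" (no result reported) as its result. Compound 3 `C[C@@H]1CN(c2c(C#N)c(C(F)(F)F)nn2-c2ccc(S(C)(=O)=O)cn2)[C@H](C)CO1` gives > 200 ug/mL as its reading, and this is a limit, not a number.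

Compound 4 `CC1CCCN(c2c(C#N)c(C(F)F)nn2-c2ccc(S(C)(=O)=O)cc2)C1` is still to be measured. The change to follow is 3-methylpiperidin-1-yl in place of phenyl on an aromatic carbon with 3-methylpiperidin-1-yl in place of phenyl on an aromatic carbon, next to the ring atom that bears a cyano group.

For the measured compounds named here, no measured pair supplies a step, and compound 2 offers no number to step from. For this exchange in this assay a moderate upward step is expected, though that expectation is loosely held and cannot yet be tested. Compound 4 is expected at 30 ug/mL as its reading, with an estimated range from 5 ug/mL to 150 ug/mL for the measurement.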

Compound 4, solubility: 50 ug/mL
The estimate for compound 4 lay 1.7-fold (0.22 log units) below the measured number, and the stated range covers the measured number.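

No step can be read for compound 4 in this assay, as compound 2, which differs from it in one place, has no single number. The compounds shown leave open how far 3-methylpiperidin-1-yl in place of phenyl moves the this assay reading.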